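Trimming One Propyl Chain on the Amide Nitrogen

This account rests on a few compounds, and the source may have more. Where it says the series, first, only, none or still open, it means among the compounds named here.

In a functional assay on the whole organism with Mus musculus as the target (on this read-out higher numbers stand for an effect only at larger amounts of compound and lower numbers for an effect already at smaller amounts), compound 1 (`CCCNC(=O)Cn1c(-c2ccc(Cl)cc2)nc2cccnc21`) gives 37.5 mg/kg, while compound 2 (`CCCN(CCC)C(=O)Cn1c(-c2ccc(Cl)cc2)nc2cccnc21`) gives 11 mg/kg, the lower of the two numbers. Compound 3 (`CCCN(C)C(=O)Cn1c(-c2ccc(Cl)cc2)nc2cccnc21`) has not yet been measured. It differs from compound 2 by hydrogen in place of ethyl on a saturated chain carbon bound to an amide-type nitrogen, which reads as propyl to methyl. Among the measured compounds shown here, one measured step bears on this change: a 3.4-fold lower number from compound 1 to compound 2 (0.53 log units; beyond the scatter), with propyl in place of hydrogen on an amide-type nitrogen. Compound 3 keeps a methyl where compound 1 has hydrogen and compound 2 has propyl, so only part of that modest step is expected to be reversed. The expected change is a 1.8-fold higher number from compound 2 to compound 3 (0.26 log units; within the scatter). For compound 3 the estimate is 20 mg/kg, with an expected range of 10 mg/kg to 40 mg/kg.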

Compound 3, dose for half-maximal effect: 11.6 mg/kg
Compound 3: the middle estimate sits 1.7-fold (0.24 log units) above what was measured; low and high end bracket the measured number.
By their numbers in this assay, from the lowest: compounds 2 and 3 (each within the scatter of the next); then compound 1.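

In this assay, propyl and methyl on the amide nitrogen cannot be told apart, with a 1.1-fold higher number from compound 2 to compound 3 (0.02 log units; within the scatter), so the full second propyl chain of compound 2 is not needed to keep this level. The larger difference lies with the amide hydrogen: methyl in its place gives a 3.2-fold lower number from compound 1 to compound 3 (0.51 log units; beyond the scatter), a step beyond the scatter, so among these compounds the smallest chain shown already separates compound 3 from compound 1. Nothing available gives a reason for this behaviour at the amide nitrogen.

From the compounds shown here alone, whether ethyl or a longer chain such as butyl on that nitrogen would stay level with compound 2 and compound 3 remains open. Also open, going by these compounds, is what happens when the remaining propyl is changed, for example to methyl or to a cyclopropyl group.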